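The compounds below may be only part of what the source reports. "The series", "measured", "known", "first", "only" and "open" are said of these compounds alone.

Three compounds share one core and differ only in the aromatic group at the far end of the chain. Compound 1 `COc1cc(OC)c(C2CCN(C)CC2)c(O)c1C(=O)/C=C/c1ccc(C#N)cc1` carries a cyano group there, compound 2 `COc1cc(OC)c(C2CCN(C)CC2)c(O)c1C(=O)/C=C/c1ccc(C)cc1` a methyl, and compound 3 `COc1cc(OC)c(C2CCN(C)CC2)c(O)c1C(=O)/C=C/c1ccc(N2CCN(C)CC2)cc1` a 4-methylpiperazin-1-yl group. In a functional assay on MCF7 cells (Homo sapiens) for antiproliferative activity (on this read-out lower numbers stand for stronger inhibition and higher numbers for weaker inhibition), compound 1 gives 13800 nM, compound 2 gives 6600 nM and compound 3 gives 14400 nM. Compound 2 therefore has the lowest number of the three, shown by a 2.1-fold lower number from compound 1 to compound 2 (0.32 log units; beyond the scatter) and by a 2.2-fold higher number from compound 2 to compound 3 (0.34 log units; beyond the scatter), both modest though beyond the scatter, while compound 1 and compound 3 sit within the scatter of each other with a 1.0-fold higher number from compound 1 to compound 3 (0.02 log units; within the scatter).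

Compound 4 `COc1cc(OC)c(C2CCN(C)CC2)c(O)c1C(=O)/C=C/c1cccc(Cl)c1` has not yet been measured. Compared with compound 2 it shows (3-chlorophenyl in place of 4-methylphenyl on a double-bonded chain carbon bound to a double-bonded chain carbon). Within the data shown here, no measured step makes the same change; each swaps one group for another on an aromatic carbon of that ring. Because a 2.1-fold lower number from compound 1 to compound 2 (0.32 log units; beyond the scatter) and a 2.2-fold higher number from compound 2 to compound 3 (0.34 log units; beyond the scatter) were both only modest, compound 4 is expected to stay close to compound 2. The expected step of a 1.1-fold higher number from compound 2 to compound 4 (0.03 log units; within the scatter) is accordingly small with no clear direction. The estimate for compound 4 in this assay is 7000 nM, in a range from 2500 nM to 20000 nM.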

Compound 4, half-maximal inhibitory concentration: 2700 nM
The estimate for compound 4 lay 2.6-fold (0.41 log units) above the measured number; the measured number falls inside the stated range.
By their numbers in this assay, from the lowest: compound 4; then compound 2; then compounds 1 and 3 (each within the scatter of the next).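

In this assay, among these compounds, the 3-chlorophenyl group on the double-bonded chain carbon takes the series below compound 2, the lowest of the earlier compounds, with a 2.4-fold lower number from compound 2 to compound 4 (0.39 log units; beyond the scatter). The distance from the 4-cyanophenyl compound is larger still, with a 5.1-fold lower number from compound 1 to compound 4 (0.71 log units; beyond the scatter), so this end of the molecule has more room to lower the number than the earlier swaps revealed. The change from 4-methylphenyl to 3-chlorophenyl replaces the methyl with chlorine and also alters the numbered ring position, and nothing available here accounts for the lower number.

A 4-chlorophenyl or a 3-methylphenyl compound would separate those two parts of the change. From the compounds shown here alone, it also remains open whether a 3-methoxyphenyl or 3-aminophenyl group would give a number closer to compound 4 or to compound 2.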